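Aryl sulfonate variation on a shared benzofuran-derived enamide core

The source may report more compounds than this note shows. Statements on the series, on what has been measured and on what is new or still open speak of the compounds shown alone.

The measured compounds are compound 1 `CNC(=O)/C=C1/COc2cc(OS(=O)(=O)c3cccc(Cl)c3)ccc21` with 41 nM, compound 2 `CNC(=O)/C=C1/COc2cc(OS(=O)(=O)c3ccc(C#N)cc3)ccc21` with 45 nM, and compound 3 `CNC(=O)/C=C1/COc2cc(OS(=O)(=O)c3ccc(S(C)(=O)=O)cc3)ccc21` with 19 nM, all in an assay (strain Sprague-Dawley) for inhibition of Amine oxidase [flavin-containing] A (Rattus norvegicus), read by spectrophotometry, with a stated time of 5 min; on this read-out lower numbers stand for stronger inhibition and higher numbers for weaker inhibition.

Compound 3 gives the lowest of the three numbers in this assay; compound 1 stands nearest to it and compound 2 furthest, with both gaps beyond the scatter. Compound 4 `CNC(=O)/C=C1/COc2cc(OS(=O)(=O)c3ccc(OC)cc3)ccc21` differs from compound 3 by methoxy in place of methylsulfonyl on an aromatic carbon. Among the measured compounds shown here, two measured steps bear on this change at the same position of the aryl sulfonate: a 1.1-fold higher number from compound 1 to compound 2 (0.04 log units; within the scatter), and a 2.4-fold lower number from compound 2 to compound 3 (0.37 log units; beyond the scatter). For the measured compounds named here, the groups seen at this position have so far shifted the number only modestly, and the methoxy group is new, so no measured step speaks for it directly. He therefore expects a small step back, a 2.0-fold higher number from compound 3 to compound 4 (0.30 log units; within the scatter), of a size that may barely exceed the scatter. Compound 4 is estimated at 38 nM, with a range from 15 nM to 95 nM.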

Compound 4, half-maximal inhibitory concentration: 11 nM
Compound 4: the middle estimate sits 3.5-fold (0.54 log units) above what was measured; the whole stated range lies above it.
By their numbers in this assay, from the lowest: compounds 4 and 3 (each within the scatter of the next); then compounds 1 and 2 (each within the scatter of the next).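

In this assay, methoxy in place of methylsulfonyl on the aromatic carbon gives a 1.7-fold lower number from compound 3 to compound 4 (0.24 log units; within the scatter), so this position takes both groups without a change that can be told from the scatter, although methoxy has fewer heavy atoms and hydrogen-bond acceptors. The same methoxy stands apart from the cyano group (a 4.1-fold lower number from compound 2 to compound 4 (0.61 log units; beyond the scatter)) and from the 3-chlorophenyl sulfonate (a 3.7-fold lower number from compound 1 to compound 4 (0.57 log units; beyond the scatter)), which places compound 3 and compound 4 together, clear of compound 2 and compound 1. The data shown offer no measured explanation for this grouping.

As far as these compounds go, whether the number holds with an amine, a carboxylic acid or a longer chain such as ethoxy on this carbon remains open. So does whether methoxy would give a similar number on another carbon of the ring.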